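From a Limit to Thiophen-3-yl in Compound 4

A few compounds are considered here, and "the series" means these few. Any claim that something is new, unique, unknown or untested is made for them only; others in the source may bear on it.

In a functional assay on SK-MEL-28 cells (Homo sapiens) for inhibition, read by MTT assay, with a stated time of 48 h (a lower number here means a stronger inhibitor, a higher number a weaker inhibitor), compound 1 `CCc1ccc(-c2nc3ccccn3c2Sc2ccccc2)cc1` gives > 100000 nM, which is a limit of the assay and not a number. For the measured compounds named here, it is the one compound at the limit of > 100000 nM in this assay, at which 1 of the 3 values shown sits. Compound 2 `Clc1ccc(Sc2c(-c3cccs3)nc3ccccn23)cc1` gives 77300 nM, and compound 3 `Clc1ccc(Sc2c(-c3ccccc3)nc3ccccn23)cc1` gives 74000 nM. Compound 4 `c1ccc(Sc2c(-c3ccsc3)nc3ccccn23)cc1`, not yet measured, has thiophen-3-yl in place of 4-ethylphenyl on an aromatic carbon. Going by the values given here, the only measured step bearing on this is a 1.0-fold lower number from compound 2 to compound 3 (0.02 log units; within the scatter), phenyl in place of thiophen-2-yl, which lies within the scatter. On that basis only a small change is expected in this assay, and the estimated step is an at least 1.2-fold lower number from compound 1 to compound 4 (0.09 log units; that floor lies within the scatter). Compound 4 is expected at 80000 nM, within an estimated range of 40000 nM to 150000 nM.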

Compound 4, half-maximal inhibitory concentration: 69300 nM
Compound 4: middle estimate off by 1.2-fold (0.06 log units), on the high side, and the stated range covers the measured number.
By their numbers in this assay, from the lowest: compounds 4, 3 and 2 (each within the scatter of the next). At a limit, above all of these: compound 1.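

In this assay the exchange of 4-ethylphenyl for thiophen-3-yl gives an at least 1.4-fold lower number from compound 1 to compound 4 (0.15 log units; that floor lies within the scatter) and so sets only a floor on the step. The value of compound 1 is a limit, so the full size of this step cannot be read: the limit of > 100000 nM in this assay, at which 1 of the 4 values shown sits. Even so, this is the first step shown at this position that involves 4-ethylphenyl, and its floor does not reach beyond the scatter.

The compounds shown leave open whether an amine, a carboxylic acid or a longer chain at this position would bring a change beyond the scatter.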